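This account rests on a few compounds, and the source may have more. Where it says the series, first, only, none or still open, it means among the compounds named here.

In a functional assay on HCT-116 cells (Homo sapiens) for antiproliferative activity, read by MTT assay, with a stated time of 72 h (a higher number here means a weaker inhibitor, a lower number a stronger inhibitor), two compounds sharing one core have been measured so far. Compound 1 `O=C(CCc1cccc2c1B(O)OC2)Nc1ccccc1` gives 350 nM, while compound 2 `COc1cc(OC)cc(-c2cccc(NC(=O)CCc3cccc4c3B(O)OC4)c2)c1` gives 53 nM, the lower of the two numbers and so the stronger inhibitor of the pair. Compound 3 `CSc1ccc(-c2cccc(NC(=O)CCc3cccc4c3B(O)OC4)c2)cc1` differs from compound 2 in one place, on an aromatic carbon of a six-membered aromatic ring of carbon only, meta to a large group: 4-(methylsulfanyl)phenyl in place of 3,5-dimethoxyphenyl on an aromatic carbon. Put simply, 4-(methylsulfanyl)phenyl stands in place of 3,5-dimethoxyphenyl.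

For the measured compounds named here, only one measured step bears on this change. Putting 3,5-dimethoxyphenyl in place of hydrogen gave a 6.6-fold lower number from compound 1 to compound 2 (0.82 log units; beyond the scatter), a modest step. That step brought in a whole ring, whereas compound 3 keeps such a ring at the same place and changes only the groups on it. Going by the values given here, no measured pair isolates a change of that kind, so no step beyond the scatter is expected in this assay, in either direction. The estimated change is a 1.1-fold higher number from compound 2 to compound 3 (0.05 log units; within the scatter). The expected value for compound 3 is 60 nM, within an estimated range of 20 nM to 180 nM.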

Compound 3, half-maximal inhibitory concentration: 180 nM
Compound 3: the middle estimate sits 3.0-fold (0.48 log units) below what was measured; the range from low to high includes it.
By their numbers in this assay, from the lowest: compound 2; then compounds 3 and 1 (each within the scatter of the next).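

In this assay this position responds to what the added ring carries, and not only to the presence of a ring: with the same six-membered aromatic ring of carbon only on the same aromatic carbon, 4-(methylsulfanyl)phenyl in place of 3,5-dimethoxyphenyl gives a step beyond the scatter (a 3.4-fold higher number from compound 2 to compound 3 (0.53 log units; beyond the scatter)). Adding a ring at this place therefore does not by itself bring a clear gain, as 4-(methylsulfanyl)phenyl in place of hydrogen stays within the scatter (a 1.9-fold lower number from compound 1 to compound 3 (0.29 log units; within the scatter)), so the gain seen with 3,5-dimethoxyphenyl does not extend to both ring groups shown here. No measurement is available that would explain the difference between these two ring groups.

From the compounds shown here alone, only hydrogen and these two ring groups appear at this position, so it remains open whether the lower number of compound 2 needs both methoxy groups or would persist with a single one. Going by these compounds, it is also open how the number would move if the added ring carried an amine or a carboxylic acid.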